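The compounds below may be only part of what the source reports. "The series", "measured", "known", "first", "only" and "open" are said of these compounds alone.

Working notes on a small set of analogues sharing one core, all read in a functional assay on MCF7 cells (Homo sapiens) for cytotoxicity, read by MTT assay, with a stated time of 24 h, tested at 0.64 ug/mL; a higher number here means a stronger effect of the compound at the concentration tested, a lower number a weaker effect.

Compound 1 `Cn1c(-c2ccc(NC(=O)CSc3nc4ccccc4o3)cc2)nc(-c2ccccc2)c1-c1ccccc1` gives 18.7% in this assay. Compound 2 `Cc1ccc2oc(SCC(=O)Nc3ccc(-c4nc(-c5ccccc5)c(-c5ccccc5)n4C)cc3)nc2c1` carries one change against it, (methyl in place of hydrogen on an aromatic carbon), and in this assay compound 2 gives 1.1%. The step of a number 17.6 percentage points lower from compound 1 to compound 2 (beyond the scatter) is the only measured effect of this kind of change in the set so far.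

Compound 3 `Cn1c(-c2ccc(NC(=O)CN3CCN(Cc4ccccc4)CC3)cc2)nc(-c2ccccc2)c1-c1ccccc1` replaces the side chain of compound 1 by a benzylpiperazine-bearing one; how the two cores differ is not broken down here. In this assay compound 3 gives 7.2%, which sits within the scatter of the number for compound 2, while compound 1 stands higher than compound 3 by more than the scatter.

Compound 4 `Cc1ccc(CN2CCN(CC(=O)Nc3ccc(-c4nc(-c5ccccc5)c(-c5ccccc5)n4C)cc3)CC2)cc1` is not yet measured. Against compound 3 it carries methyl in place of hydrogen on an aromatic carbon. This is the same kind of change as between compound 1 and compound 2, not the same: in compound 2 the methyl sits on a ring that is part of a fused or bridged system of two rings, meta and para to a fused ring, whereas in compound 4 it sits on a six-membered aromatic ring of carbon only, para to a large group.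

Among the measured compounds shown here, the only guide is the step from compound 1 to compound 2, which was downward by a modest amount. Compound 3 starts low, so the room to fall is limited; a smaller downward step a number 4.2 percentage points lower from compound 3 to compound 4 (within the scatter) is expected for compound 4 because the earlier step of a number 17.6 percentage points lower from compound 1 to compound 2 (beyond the scatter) pointed downward. Compound 4 is estimated at 3%, expected between 0% and 12%.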

Compound 4, a percentage reported as activity, at one concentration (the size of the read-out at that concentration, not a potency): 9.4%
Compound 4: the middle estimate sits 6.4 percentage points below what was measured, within the range that was stated.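

In this assay, methyl in place of hydrogen on an aromatic carbon does not carry over as a fixed step from one core to the other: the same change on two cores in this assay, a number 17.6 percentage points lower (beyond the scatter) from compound 1 to compound 2 and a number 2.2 percentage points higher (within the scatter) from compound 3 to compound 4, 19.8 percentage points apart, beyond the scatter of two such steps. With the benzylpiperazine-bearing side chain the step is a number 2.2 percentage points higher from compound 3 to compound 4 (within the scatter), so benzyl to 4-methylbenzyl gives no resolved change, and the clear fall seen with the first matched pair does not reappear. This does not show why the two steps part, since a single pair on each core cannot separate the place of the methyl from the side chain around it, and readings at one concentration say nothing about potency.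

The compounds shown leave open whether either result is specific to methyl, since a methoxy group, a chlorine atom or a carboxylic acid in its place could give a different step on each core. They also leave open whether the gap between the two steps would persist with a longer chain linking the amide carbonyl to the piperazine or to the sulfur.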